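Expecting a Methyl Group's Effect on Cell Growth Inhibition

The source may report more compounds than this note shows. Statements on the series, on what has been measured and on what is new or still open speak of the compounds shown alone.

Measured in a functional assay on HeLa cells (Homo sapiens) for cytotoxicity, read by MTT assay, with a stated time of 72 h, tested at 30 uM; a higher number here means more inhibition of growth at the concentration tested, a lower number less inhibition of growth:
compound 1 `N/C(=N\NC(=S)N1CCCCCC1)c1ccccn1`: 82.9%
compound 2 `N/C(=N\NC(=S)N1CCCCC1)c1ccccn1`: 76.9%
compound 3 `Cc1cccc(/C(N)=N/NC(=S)N2CCCCC2)n1`: 83.5%

Compound 2 and compound 3 share a core, and the step of a number 6.6 percentage points higher from compound 2 to compound 3 (within the scatter) came with this change: methyl in place of hydrogen on an aromatic carbon. Compound 1 has a different core from compound 2; the difference between the two cores is not broken down here, and the two values in this assay are within the scatter of each other.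

Compound 4 `Cc1cccc(/C(N)=N/NC(=S)N2CCCCCC2)n1` has not yet been measured. It differs from compound 1 by methyl in place of hydrogen on an aromatic carbon, the same change, at the same place, as between compound 2 and compound 3.

Compound 4 is expected to give 86% in this assay, with a range of 76% to 95%. The expected step is a number 3.1 percentage points higher from compound 1 to compound 4 (within the scatter), small like the measured one, because compound 3 reached 83.5% and compound 1 already stands near it.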

Compound 4, percent growth inhibition at one concentration: 81.2%
Estimate against measurement, compound 4: 4.8 percentage points above; measured number inside the range.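

In this assay, placing methyl in place of hydrogen on an aromatic carbon gave a step of a number 1.7 percentage points lower from compound 1 to compound 4 (within the scatter). Set beside the same change on the other core, the two steps do not differ measurably: the same change on two cores in this assay, a number 6.6 percentage points higher (within the scatter) from compound 2 to compound 3 and a number 1.7 percentage points lower (within the scatter) from compound 1 to compound 4, 8.3 percentage points apart, within the scatter of two such steps. The change therefore behaves alike on these two cores as far as this assay can tell, but neither step stands clear of the scatter, so this does not show that methyl raises or lowers growth inhibition on either core, and two cores cannot speak for the whole series.

The compounds shown leave open whether a different group at this place, such as ethyl, methoxy or chlorine, would give a step beyond the scatter. They also leave open how a methyl group would act elsewhere on the ring.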